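The source may hold more compounds than are shown below. What is called first, only, known or untested is meant among the compounds shown, and "the series" means these compounds.

Compound 1, `COc1cc2c(Nc3ccc(C#N)cc3)ncnc2cc1OCCCN(C)Cc1ccccc1`, in a functional assay on SH-SY5Y cells (Homo sapiens) for antiproliferative activity, read by MTT assay, with a stated time of 72 h (on this read-out higher numbers stand for weaker inhibition and lower numbers for stronger inhibition), gives > 100000 nM; this is a limit of the assay rather than a number.
Compound 2, `COc1cc2c(Nc3ccc(C#N)cc3)ncnc2cc1OCCCN1CCC(CO)CC1`, in this assay gives 21600 nM.

Going by the values given here, compound 2 thus holds the only plain number so far, since the other value shown is only a limit. Among the compounds with values here, the single measured step, an at least 4.6-fold lower number from compound 1 to compound 2 (0.66 log units; beyond the scatter), concerns the amine at the end of the chain, and its size rests on the limit of > 100000 nM in this assay, at which 1 of the 2 values shown sits, rather than on two known numbers. Compound 3, `COc1cc2c(Nc3ccc(C#N)cc3)ncnc2cc1OCCCN1CCC(c2ccccc2)CC1`, keeps the six-membered ring of compound 2 but carries phenyl in place of hydroxymethyl on a saturated ring carbon. Within the data shown here, no measured step touches that position, so the earlier step offers only indirect guidance, and the expected movement, a 1.4-fold lower number from compound 2 to compound 3 (0.16 log units; within the scatter), is kept small in either direction. Compound 3 is estimated at 15000 nM, with a range from 4000 nM to 60000 nM.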

Compound 3, half-maximal inhibitory concentration: 7770 nM
Estimate against measurement, compound 3: 1.9-fold (0.29 log units) above; low and high end bracket the measured number.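

The ring carbon three ring bonds from the ring nitrogen affects the result in this assay: with the rest of the molecule unchanged, phenyl in place of hydroxymethyl gives a 2.8-fold lower number from compound 2 to compound 3 (0.44 log units; beyond the scatter), so the hydroxymethyl group is not required for the activity seen here. Measured against the benzyl(methyl)amino group, 4-phenylpiperidin-1-yl gives an at least 12-fold lower number from compound 1 to compound 3 (1.10 log units; beyond the scatter). That step starts from a limit of the assay, not a number: the limit of > 100000 nM in this assay, at which 1 of the 3 values shown sits.

With only two groups compared at this ring carbon, the compounds shown cannot separate the effect of adding an aromatic ring from that of removing the hydroxyl, and a cyclohexyl group or a carboxylic acid there would test this further. Also open, from the compounds shown here alone, is how a longer chain between the oxygen and the ring nitrogen would change the number.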